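The source may report more compounds than this note shows. Statements on the series, on what has been measured and on what is new or still open speak of the compounds shown alone.

Measured so far in an assay on isolated protein with Bile acid receptor (Homo sapiens) as the target; a lower number here means that less compound is needed, a higher number that more compound is needed for the effect:
Compound 1 `COC(=O)/C=C/c1cccc(N(Cc2ccc(-c3ccc(F)c(F)c3)cc2)C(=O)C2CCCCC2)c1`: 72 nM.
Compound 3 `CCOC/C=C/c1ccc(CN(C(=O)C2CCCCC2)c2cccc(/C=C/C(=O)OC)c2)cc1`: 198000 nM.
Compound 2 `CCOC(=O)/C=C/c1ccc(CN(C(=O)C2CCCCC2)c2cccc(/C=C/C(=O)OC)c2)cc1`: reported only as a limit, > 1000 nM; see (the limit of > 1000 nM in this assay, at which 1 of the 3 values shown sits).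

Going by the values given here, compound 3 carries the highest of the two readable numbers in this assay; the only readable step reaching it is a 2800-fold higher number from compound 1 to compound 3 (3.44 log units; beyond the scatter).

Compound 4 `COC(=O)/C=C/c1cccc(N(Cc2ccc(-c3cccc(C(C)=O)c3)cc2)C(=O)C2CCCCC2)c1` differs from compound 3 as follows: 3-acetylphenyl in place of 3-ethoxyprop-1-en-1-yl on an aromatic carbon. The measured step that bears on this is a 2800-fold higher number from compound 1 to compound 3 (3.44 log units; beyond the scatter), a large one, in which a six-membered aromatic ring of carbon at that position stood against the 3-ethoxyprop-1-en-1-yl chain. Compound 4 restores such a ring, so a large fall is expected, a 1300-fold lower number from compound 3 to compound 4 (3.12 log units; beyond the scatter). Compound 4 is estimated at 150 nM, with a range of 40 nM to 1000 nM.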

Compound 4, half-maximal effective concentration: 227 nM
Compound 4: the middle estimate sits 1.5-fold (0.18 log units) below what was measured, and the stated range covers the measured number.
By their numbers in this assay, from the lowest: compound 1; then compound 4; then compound 3.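

In this assay, the gain at this position is not tied to the 3,4-difluorophenyl group: 3-acetylphenyl, also a six-membered aromatic ring of carbon, gives an 870-fold lower number from compound 3 to compound 4 (2.94 log units; beyond the scatter). The two rings are not equivalent, with a 3.2-fold higher number from compound 1 to compound 4 (0.50 log units; beyond the scatter), so what the ring carries also moves the number. The comparison with the 2-(ethoxycarbonyl)ethenyl chain, an at least 4.4-fold lower number from compound 2 to compound 4 (0.64 log units; beyond the scatter), rests on a limit: the limit of > 1000 nM in this assay, at which 1 of the 4 values shown sits.

Open, from the compounds shown here alone, is how an unsubstituted phenyl ring would read at this position. Also open, going by these compounds, is the effect of a carboxylic acid or an amine on that ring.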